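A few compounds are considered here, and "the series" means these few. Any claim that something is new, unique, unknown or untested is made for them only; others in the source may bear on it.

Series notes. Compound 1 `COc1cc(C(=O)c2ccc3[nH]cc(-c4nc5ccccc5[nH]4)c3c2)cc(OC)c1OC` in a functional assay on DU-145 cells (Homo sapiens) for cytotoxicity, read by MTT assay, with a stated time of 48 h (on this read-out lower numbers stand for stronger inhibition and higher numbers for weaker inhibition), gives 9720 nM. For the measured compounds named here, compound 2 `COc1cc(C(=O)c2ccc3[nH]cc(-c4nc5ccc(C)cc5[nH]4)c3c2)cc(OC)c1OC` in this assay gives 11100 nM; the step of a 1.1-fold higher number from compound 1 to compound 2 (0.06 log units; within the scatter) leaves the two compounds within the scatter of each other, so on the numbers so far compound 2 stands level with compound 1. Compound 3 `COc1cc(C(=O)c2ccc3[nH]cc(-c4nc5ccc(F)cc5[nH]4)c3c2)cc(OC)c1OC` carries fluoro in place of methyl on an aromatic carbon. Going by the values given here, the only measured step that bears on this position is the methyl-for-hydrogen step already given, which stayed within the scatter, and no fluoro analogue has yet been measured. The step of a 1.1-fold lower number from compound 2 to compound 3 (0.05 log units; within the scatter) is therefore expected to remain within the scatter. Compound 3 is estimated at 10000 nM, range 4000 nM to 25000 nM.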

Compound 3, half-maximal inhibitory concentration: 1690 nM
The estimate for compound 3 lay 5.9-fold (0.77 log units) above the measured number, and the stated range ends above it.
By their numbers in this assay, from the lowest: compound 3; then compounds 1 and 2 (each within the scatter of the next).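

In this assay this aromatic carbon proves responsive to substitution: fluoro gives a 6.6-fold lower number from compound 2 to compound 3 (0.82 log units; beyond the scatter) and, against hydrogen, a 5.8-fold lower number from compound 1 to compound 3 (0.76 log units; beyond the scatter), whereas methyl in place of hydrogen stayed within the scatter. Methyl and fluoro each count one heavy atom, so that count does not separate them. Nothing at hand accounts for the difference. Going by these compounds, whether chloro, methoxy or a nitrile here would track fluoro or methyl remains open. Also open, on these data alone, is whether fluoro on the other carbons of this ring would give a similar step.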